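The source may hold more compounds than are shown below. What is called first, only, known or untested is meant among the compounds shown, and "the series" means these compounds.

In a functional assay on PC-3 cells (Homo sapiens) for antiproliferative activity, read by MTT assay, with a stated time of 72 h (on this read-out higher numbers stand for weaker inhibition and lower numbers for stronger inhibition), the measured compounds stand as follows:

Compound 1 `O=C(N/N=C/c1ccccc1)Nc1ccc(Oc2ccnc3[nH]ccc23)c(F)c1` gives 7940 nM
Compound 2 `COc1ccc(/C=N/NC(=O)Nc2ccc(Oc3ccnc4[nH]ccc34)c(F)c2)c(OC)c1OC` gives 8970 nM
Compound 3 `O=C(N/N=C/c1ccccc1)Nc1ccc(Oc2ccnc3[nH]ccc23)cc1` gives 10200 nM

Compound 3 at 10200 nM lies within the usual scatter of both compound 1 and compound 2, so the three numbers form a single level in this assay and cannot be ranked. Compound 4 `COc1ccc(/C=N/NC(=O)Nc2ccc(Oc3ccnc4[nH]ccc34)cc2)cc1` is compound 3 with methoxy in place of hydrogen on an aromatic carbon, para to a large group, which turns phenyl into 4-methoxyphenyl (methoxy in place of hydrogen on an aromatic carbon).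

Going by the values given here, no measured step makes exactly this change. The only one available is a different swap, hydrogen in place of fluoro on an aromatic carbon, and it gives a 1.3-fold higher number from compound 1 to compound 3 (0.11 log units; within the scatter) as its result. The nearest evidence comes from a comparison of two fluoro compounds. Compound 2 carries methoxy groups on the ring that stands bare in compound 1, yet compound 1 at 7940 nM and compound 2 at 8970 nM are within the scatter of each other. On this evidence, no step beyond the scatter is expected in this assay for the new methoxy. The expected result is a 1.1-fold lower number from compound 3 to compound 4 (0.05 log units; within the scatter) as an estimate. For compound 4 the estimated value is 9000 nM with an expected range from 4000 nM to 18000 nM in this assay.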

Compound 4, half-maximal inhibitory concentration: "not active" (no number reported)
Nothing numeric was reported for compound 4; there is nothing to compare the estimate with.
By their numbers in this assay, from the lowest: compounds 1, 2 and 3 (each within the scatter of the next).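

In this assay, going by these compounds alone, compound 4 is reported as not active, with no number, so no step from compound 3 to compound 4 can be read. Nothing measured here accounts for that result. The compounds shown leave open how large the effect of swapping phenyl for 4-methoxyphenyl is on this read-out.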